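This account rests on a few compounds, and the source may have more. Where it says the series, first, only, none or still open, it means among the compounds named here.

Measured compounds:
- compound 1 `COc1ccc(NC(=S)NC2CC(C)(C)Oc3ccc(Br)cc32)cc1`: in a functional assay on T98G cells (Homo sapiens) for inhibition, read by MTT assay, with a stated time of 72 h (on this read-out lower numbers stand for stronger inhibition and higher numbers for weaker inhibition), compound 1 gives 33000 nM
- compound 2 `CCNC(=O)NC1CC(C)(C)Oc2ccc(Cl)cc21`: in this assay compound 2 gives "not determined" (no result reported)

Among the compounds with values here, compound 1 is the only member of the series with a number in this assay, and that number places it at the weak end of what the read-out resolves. Within the data shown here, compound 2 adds no figure, so no pair of measured compounds is available to show how large a single change moves the read-out.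

Compound 3 `CC1(C)CC(NC(=S)Nc2ccc(C#N)cc2)c2cc(Br)ccc2O1` has not been measured. It differs from compound 1 by cyano in place of methoxy on an aromatic carbon, which amounts to an exchange of a 4-methoxyphenyl for a 4-cyanophenyl on the thiourea.

Among the measured compounds shown here, with no measured step to lean on, the change from compound 1 to compound 3 is expected to be small, with no clear direction and probably not beyond the scatter of this assay. For compound 3 the expected result in this assay is 25000 nM, within 8000 nM to 80000 nM, a step of a 1.3-fold lower number from compound 1 to compound 3 (0.12 log units; within the scatter).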

Compound 3, half-maximal inhibitory concentration: 24000 nM
Compound 3: the middle estimate sits 1.0-fold (0.02 log units) above what was measured; low and high end bracket the measured number.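

Within the data shown here, this is the first measured step: in this assay, the exchange of methoxy for cyano on the aromatic carbon gives a 1.4-fold lower number from compound 1 to compound 3 (0.14 log units; within the scatter). The 4-methoxyphenyl and 4-cyanophenyl groups therefore cannot be told apart on this read-out, and this one pair shows that the position accepts both groups, which have the same heavy-atom count and hydrogen-bond acceptor count, without a change beyond the scatter. No supporting evidence bears on this result, so the near-identity of the pair stays unexplained.

From the compounds shown here alone, whether an amine or a carboxylic acid on the same aromatic carbon would shift the read-out beyond the scatter remains open. Also open, going by these compounds, is the effect of a longer alkyl chain in place of the aryl group on the thiourea.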